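The source may hold more compounds than are shown below. What is called first, only, known or untested is meant among the compounds shown, and "the series" means these compounds.

Measured compounds:
Compound 1 `Nc1nc2cc(-c3nn(CCCC(=O)NO)c4ncnc(N)c34)ccc2o1` – in a functional assay on CNE-2 cells (Homo sapiens) for inhibition, read by MTT assay, with a stated time of 72 h (a lower number here means a stronger inhibitor, a higher number a weaker inhibitor), compound 1 gives > 50000 nM, which is a limit of the assay and not a number.
Compound 2 `Nc1ncnc2c1c(-c1cnc3[nH]ccc3c1)nn2CCCCC(=O)NO` – in this assay compound 2 gives > 150000 nM, again a limit of the assay and not a number.

Both values shown are limits, so compound 1 cannot be placed on a scale of inhibitors: its measurement stopped at the limit of > 50000 nM in this assay, at which 1 of the 2 values shown sits. For compound 2 the measurement stopped at the limit of > 150000 nM in this assay, at which 1 of the 2 values shown sits. Neither compound showed measurable inhibition in this assay within the range tested.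

Compound 3 `Nc1nc2cc(-c3nn(CCCCC(=O)NO)c4ncnc(N)c34)ccc2o1` differs from compound 1 in one place: (hydroxycarbamoyl)methyl in place of hydroxycarbamoyl on a saturated chain carbon, three bonds along the chain from an aromatic nitrogen. The chain that carries the hydroxamic acid group is lengthened by a single carbon, and everything else in the shared core is kept.

For the measured compounds named here, no step between measured compounds has been recorded, so there is no comparison to lean on. With both known values sitting at limits, the expectation in this assay is no change beyond the scatter, and most likely another limit. The step from compound 1 to compound 3 is estimated as a step that the limit leaves unreadable from compound 1 to compound 3. Compound 3 is therefore expected to give about 60000 nM, with a range from 15000 nM to 250000 nM.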

Compound 3, half-maximal inhibitory concentration: > 50000 nM
Compound 3 ended at the assay's limit; the forecaster's own chance of this, stated with the estimate: 70%; the middle value does not contradict the limit.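

No step can be read from compound 1 to compound 3 in this assay: each of the two ended at a limit of the assay and not at a number, so the change from 3-(hydroxycarbamoyl)propyl to 4-(hydroxycarbamoyl)butyl has no readable size. The compounds shown leave open which changes to the shared core, if any, would give a measurable value in this assay.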